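The compounds below may be only part of what the source reports. "The series", "measured", "known", "first", "only" and "open" are said of these compounds alone.

Working notes on the series. In an ADME assay on microsomes from liver (Homo sapiens) for metabolic stability, tested at 2.5 uM (a lower number here means slower removal, a higher number faster removal of the compound), compound 1 `O=S(=O)(c1cc(F)cc(F)c1)c1cnc2cc(F)ccc2c1-c1cccc(F)c1` gives 0.06 mL/min. Compound 2 `Cc1ccc(S(=O)(=O)c2cnc3cc(F)ccc3c2-c2cccc(F)c2)cc1F` gives 0.41 mL/min, and compound 3 `O=S(=O)(c1cccc(F)c1)c1cnc2cc(F)ccc2c1-c1cccc(F)c1` gives 0.24 mL/min. Compound 3 thus stands second highest of the three numbers, with compound 2 within the scatter of it and compound 1 beyond the scatter below it. Compound 4 `O=S(=O)(c1ccc(F)c(Cl)c1)c1cnc2cc(F)ccc2c1-c1cccc(F)c1` differs from compound 3 in one place: 3-chloro-4-fluorophenyl in place of 3-fluorophenyl on a sulfonyl sulfur. Within the data shown here, three measured steps bear on the group on the sulfonyl sulfur: a 4.0-fold higher number from compound 1 to compound 3 (0.60 log units; beyond the scatter), a 6.8-fold higher number from compound 1 to compound 2 (0.83 log units; beyond the scatter), while a 1.7-fold lower number from compound 2 to compound 3 (0.23 log units; within the scatter). Among the measured compounds shown here, only the step to compound 1 went with a lower number, and compound 2 went the other way, so a modest lower step is expected, a 1.6-fold lower number from compound 3 to compound 4 (0.20 log units; within the scatter). Compound 4 is estimated at 0.15 mL/min, in the range 0.06 mL/min to 0.4 mL/min.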

Compound 4, intrinsic clearance in a liver preparation (reported as CLH), per the amount of preparation that the assay uses: 0.25 mL/min
Estimate against measurement, compound 4: 1.7-fold (0.22 log units) below; the range from low to high includes it.
By their numbers in this assay, from the lowest: compound 1; then compounds 3, 4 and 2 (each within the scatter of the next).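

In this assay, 3-chloro-4-fluorophenyl on the sulfonyl sulfur gives a number that cannot be told apart from that of 3-fluorophenyl (a 1.0-fold higher number from compound 3 to compound 4 (0.02 log units; within the scatter)) or 3-fluoro-4-methylphenyl (a 1.6-fold lower number from compound 2 to compound 4 (0.21 log units; within the scatter)). Compound 1, with 3,5-difluorophenyl, therefore stands apart from a third compound as well (a 4.2-fold higher number from compound 1 to compound 4 (0.62 log units; beyond the scatter)). Among these four compounds, only compound 1 lies beyond the scatter of the others.

On these data alone, whether a phenyl carrying an amine or a carboxylic acid on the sulfonyl sulfur would group with compound 1 or with the other three remains open. Nothing at hand accounts for the position of compound 1.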